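The compounds below may be only part of what the source reports. "The series", "measured", "known", "first", "only" and "open" are said of these compounds alone.

Measured so far in a functional assay on HepG2 cells (Homo sapiens) for inhibition, read by MTT assay, with a stated time of 48 h, tested at 10 uM; a lower number here means less inhibition of growth, a higher number more inhibition of growth at the concentration tested:
compound 1 `COc1ccc(C(=O)/C=C/c2ccc(OCc3cn(Cc4ccccc4Br)nn3)cc2)cc1` gives 44%;
compound 2 `COc1ccc(C(=O)/C=C/c2ccc(OCc3cn(Cc4cccc(Br)c4)nn3)cc2)cc1` gives 27%;
compound 3 `O=C(/C=C/c1ccc(OCc2cn(Cc3ccccc3Br)nn2)cc1)c1ccc([N+](=O)[O-])cc1` gives 32%.

Compound 4 `O=C(/C=C/c1ccc(OCc2cn(Cc3cccc(Br)c3)nn2)cc1)c1ccc([N+](=O)[O-])cc1` has not yet been measured. It differs from compound 3 by 3-bromophenyl in place of 2-bromophenyl on a saturated chain carbon bound to an aromatic nitrogen. The same change has been made once before, from compound 1 to compound 2, where it reads 3-bromophenyl in place of 2-bromophenyl on a saturated chain carbon bound to an aromatic nitrogen and gave a number 17 percentage points lower from compound 1 to compound 2 (beyond the scatter). The cores of the two pairs differ by nitro in place of methoxy on an aromatic carbon, a change that on its own gave a number 12 percentage points lower from compound 1 to compound 3 (beyond the scatter). Within the data shown here, since only one earlier example of this swap is known, and the place of the change is identical in both pairs, the step from compound 3 to compound 4 is expected to be of a similar size, namely a number 16 percentage points lower from compound 3 to compound 4 (beyond the scatter). On that basis compound 4 is estimated at 16%, expected to fall between 4% and 30%.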

Compound 4, percent growth inhibition at one concentration: 13%
For compound 4 the middle estimate is 3 percentage points above the measured one, within the range that was stated.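

In this assay, 3-bromophenyl in place of 2-bromophenyl gives a number 19 percentage points lower from compound 3 to compound 4 (beyond the scatter), which matches the step seen on the methoxy core: the same change on two cores in this assay, a number 17 percentage points lower (beyond the scatter) from compound 1 to compound 2 and a number 19 percentage points lower (beyond the scatter) from compound 3 to compound 4, 2 percentage points apart, within the scatter of two such steps. Nitro in place of methoxy gives a number 14 percentage points lower from compound 2 to compound 4 (beyond the scatter), and this also repeats when the bromophenyl group differs: the same change on two cores in this assay, a number 12 percentage points lower (beyond the scatter) from compound 1 to compound 3 and a number 14 percentage points lower (beyond the scatter) from compound 2 to compound 4, 2 percentage points apart, within the scatter of two such steps. In these four compounds, each change therefore carries over to the other core at much the same size, but this rests on just two cores at a single concentration and does not show why the number falls or that the step holds on any other core.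

As far as these compounds go, it remains open whether the bromophenyl step would keep its size with an amine or a carboxylic acid in place of the methoxy or nitro group.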